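Hydroxy enters a benzamide whose cytotoxicity sits at the limit

The source may hold more compounds than are shown below. What is called first, only, known or untested is meant among the compounds shown, and "the series" means these compounds.

Compound 2 `Cc1ccc(S(=O)(=O)N[C@@H](CC(=O)NC(C)(C)C)C(=O)NCCNC(=O)c2ccccc2)cc1` carries a benzoyl group on an amine nitrogen of the shared core. In an ADME assay on Karpas-1106P cells (Homo sapiens) for cytotoxicity (on this read-out lower numbers stand for an effect already at smaller amounts and higher numbers for an effect only at larger amounts of compound), compound 2 gives > 11100 nM, which is a limit of the assay and not a number. Its two measured neighbours stand the same way. Compound 1 `Cc1ccc(S(=O)(=O)N[C@@H](CC(=O)NC(C)(C)C)C(=O)NCCNS(=O)(=O)c2ccccc2)cc1`, with phenylsulfonyl in place of the benzoyl, gives > 11100 nM in this assay, again a limit. Compound 3 `Cc1ccc(S(=O)(=O)N[C@@H](CC(=O)NC(C)(C)C)C(=O)NCCNC(=O)c2ccccc2F)cc1`, with fluoro in place of hydrogen on an aromatic carbon, gives > 11100 nM in this assay, also a limit. All three values therefore sit at the limit of > 11100 nM in this assay, at which 3 of the 3 values shown sit. The step that the two limits leave unreadable from compound 2 to compound 3 is the one closest in kind to the change considered here, and the steps a step that the two limits leave unreadable from compound 1 to compound 2 and a step that the two limits leave unreadable from compound 1 to compound 3 are unreadable as well.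

Compound 4 `Cc1ccc(S(=O)(=O)N[C@@H](CC(=O)NC(C)(C)C)C(=O)NCCNC(=O)c2cccc(O)c2)cc1` differs from compound 2 by hydroxy in place of hydrogen on an aromatic carbon. For the measured compounds named here, no measured step has a readable size, so the only guidance is that three compounds with different groups on this amine nitrogen all stand at the limit; no direction can be expected, and the step of a number no higher from compound 2 to compound 4 (the limit leaves the size open) is estimated to stay within that picture. Compound 4 is accordingly expected to give 11100 nM in this assay, within 5000 nM to 30000 nM, most likely once more only as a limit.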

Compound 4, half-maximal effective concentration: > 11100 nM
Compound 4 was reported as a limit; the forecaster's own chance of this, stated with the estimate: 85%; the middle value lies on the limit itself.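

Compound 4 stands at a limit of the assay, as do compound 1, compound 2 and compound 3, so no step among these compounds can be read: the limit of > 11100 nM in this assay, at which 4 of the 4 values shown sit.

The compounds shown leave open whether hydroxy, fluoro or phenylsulfonyl changes the read-out at all in this assay, and how far any of the four lies from that limit.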